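Replacing pyridin-2-yl with methyl in compound 3

This account rests on a few compounds, and the source may have more. Where it says the series, first, only, none or still open, it means among the compounds named here.

Compound 1 `COCCOc1cc2oc(=O)n(CCC(=O)O)c2cc1Cl`: 70.7%
Compound 2 `O=C(O)CCn1c(=O)oc2cc(Cl)c(Cl)cc21`: 98.2%
Compound 3 `O=C(O)CCn1c(=O)oc2cc(OCc3ccccn3)c(Cl)cc21`: 92.6%

In an ADME assay on a cell-free system (plasma, Homo sapiens) for protein binding, compound 3 gives 92.6%, the middle of the three values, and its gaps to both others lie beyond the scatter. Compound 4 `CCOc1cc2oc(=O)n(CCC(=O)O)c2cc1Cl` has not yet been measured. The change is methyl in place of pyridin-2-yl on a saturated chain carbon bound to an oxygen on an aromatic ring, or (pyridin-2-yl)methoxy to ethoxy when cut one bond further out.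

The closest guide is a 4.0-fold lower unbound fraction from compound 1 to compound 3 (0.60 log units; beyond the scatter), with pyridin-2-yl in place of methoxymethyl at that same place. A second guide, a 4.1-fold higher unbound fraction from compound 2 to compound 3 (0.61 log units; beyond the scatter), has (pyridin-2-yl)methoxy in place of chloro and bears less directly. Taking away pyridin-2-yl should roughly reverse the first step, though no measurement separates methyl from methoxymethyl. The expected change is a 2.7-fold higher unbound fraction from compound 3 to compound 4 (0.43 log units; beyond the scatter), a modest step towards more free compound. Compound 4 is estimated at 80%, with an expected range of 68% to 90%.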

Compound 4, plasma protein binding: 95.8%
Compound 4: middle estimate off by 4.8-fold (0.68 log units) (unbound fraction), on the high side, and the stated range ends below it.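

In this assay, pyridin-2-yl and methyl cannot be told apart at this place on a saturated chain carbon bound to an oxygen on an aromatic ring, with a 1.8-fold lower unbound fraction from compound 3 to compound 4 (0.25 log units; within the scatter). The much clearer change in this side chain comes from removing the methoxy, which gives a 7.0-fold lower unbound fraction from compound 1 to compound 4 (0.84 log units; beyond the scatter), so the end of the chain matters more here than the pyridin-2-yl swap suggested. Ethoxy in place of chloro on an aromatic carbon still leaves more compound free, with a 2.3-fold higher unbound fraction from compound 2 to compound 4 (0.37 log units; beyond the scatter), though by a smaller step than compound 1 showed against compound 2.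

Nothing available gives a reason for these differences. Going by these compounds, whether a hydroxyl or an amine at the end of the ethoxy chain, or a longer chain such as propoxy, would sit nearer compound 1 or compound 4 stays open.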